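Swapping Chloro for Methyl in Compound 2

The compounds below may be only part of what the source reports. "The series", "measured", "known", "first", "only" and "open" are said of these compounds alone.

Measured so far:
Compound 1 `O=C(Nc1cccc(-c2ccccc2Cl)c1)C(Cl)Cl`: 22600 nM
Compound 2 `O=C(Nc1cccc(-c2cccc(Cl)c2)c1)C(Cl)Cl`: 21400 nM
Compound 3 `Cc1ccc(-c2cccc(NC(=O)C(Cl)Cl)c2)cc1`: 8300 nM

All three compounds were tested in a functional assay on A549 cells (Homo sapiens) for cytotoxicity, read by MTT assay, with a stated time of 68 h; a lower number here means a stronger inhibitor, a higher number a weaker inhibitor. Of the three numbers, compound 2 holds the second highest. Its nearest neighbour is compound 1, whose value sits within the usual scatter of compound 2, so the two cannot be ordered. Compound 3, which carries a methyl group rather than a chloro on its outer ring, gives 8300 nM, a number beyond the scatter and lower than that of compound 2.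

Compound 4 `Cc1cccc(-c2cccc(NC(=O)C(Cl)Cl)c2)c1` has not yet been measured. Compared with compound 2, the difference is methyl in place of chloro on an aromatic carbon. Among the compounds with values here, no step between two measured compounds describes exactly this exchange, so the expectation rests on what the set shows. Within the data shown here, compound 3 is the only measured compound with a methyl in place of a chloro, and it gives the lowest number of the three; a similar direction is expected for compound 4, though with less certainty, since no measured pair isolates this change. The step from compound 2 to compound 4 is therefore expected to be modest and downward, a 1.5-fold lower number from compound 2 to compound 4 (0.18 log units; within the scatter), and may not clear the scatter. Compound 4 is estimated at 14000 nM, with a range from 6000 nM to 35000 nM.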

Compound 4, half-maximal inhibitory concentration: 8700 nM
For compound 4 the middle estimate is 1.6-fold (0.21 log units) above the measured one; the measured number falls inside the stated range.
By their numbers in this assay, from the lowest: compounds 3 and 4 (each within the scatter of the next); then compounds 2 and 1 (each within the scatter of the next).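

In this assay, within the data shown here, methyl in place of chloro on an aromatic carbon, meta to a large group, gives a 2.5-fold lower number from compound 2 to compound 4 (0.39 log units; beyond the scatter), the first measured step in the set that isolates this exchange. Compound 3 had suggested this direction, but it differs from compound 2 in more than one place; the new pair shows the direction at this position with nothing else changed, and the size of the step is modest. Compound 4, at 8700 nM, also stands within the scatter of compound 3, at 8300 nM, so the two methyl compounds cannot be ordered, and nothing available explains the step from chloro to methyl.

The compounds shown leave open whether this lower number is particular to methyl or would also appear with another group on the same aromatic carbon, such as an ethyl, a methoxy, an amine or a carboxylic acid. They also leave open whether the same exchange would give a step of similar size on other carbons of that ring.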